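The source may report more compounds than this note shows. Statements on the series, on what has been measured and on what is new or still open speak of the compounds shown alone.

Measured compounds in a functional assay on MCF7 cells (Homo sapiens) for cytotoxicity, read by MTT assay, with a stated time of 72 h; on this read-out lower numbers stand for stronger inhibition and higher numbers for weaker inhibition:
compound 1 `Cc1cccc(-c2ccnc(C(=O)Nc3ccc(Oc4ccnc5[nH]ccc45)c(F)c3)c2)c1` gives 9120 nM
compound 2 `Cc1ccc(-c2ccnc(C(=O)Nc3ccc(Oc4ccnc5[nH]ccc45)c(F)c3)c2)c(C)c1` gives 6220 nM
compound 3 `O=C(Nc1ccc(Oc2ccnc3[nH]ccc23)c(F)c1)c1cc(-c2ccc(C(F)(F)F)cc2)ccn1` gives 8550 nM

Compound 3 stands second highest of these three numbers. The two steps leading to it, a 1.1-fold lower number from compound 1 to compound 3 (0.03 log units; within the scatter) and a 1.4-fold higher number from compound 2 to compound 3 (0.14 log units; within the scatter), both sit within the scatter, so the three measured compounds are not separated on this read-out.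

Compound 4 `O=C(Nc1ccc(Oc2ccnc3[nH]ccc23)c(F)c1)c1cc(-c2ccc(F)cc2F)ccn1` is not yet measured. It differs from compound 3 in one place: 2,4-difluorophenyl in place of 4-(trifluoromethyl)phenyl on an aromatic carbon. The measured steps that bear on this change are the three swaps of the aryl group at the same position: a 1.5-fold lower number from compound 1 to compound 2 (0.17 log units; within the scatter), a 1.1-fold lower number from compound 1 to compound 3 (0.03 log units; within the scatter) and a 1.4-fold higher number from compound 2 to compound 3 (0.14 log units; within the scatter). None of them moves beyond the scatter, whether the group carries one methyl, two methyls or a trifluoromethyl. On that basis no step beyond the scatter is expected in this assay for compound 4 either. Compound 4 is therefore estimated at 8000 nM, with a range of 3500 nM to 18000 nM. The step this estimate implies, a 1.1-fold lower number from compound 3 to compound 4 (0.03 log units; within the scatter), is expected to stay within the scatter.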

Compound 4, half-maximal inhibitory concentration: > 10000 nM
Compound 4 gave a limit, no number; the forecaster's own chance of this, stated with the estimate: 5%; middle value at least 1.2-fold (0.09 log units) away from the limit.
By their numbers in this assay, from the lowest: compounds 2, 3 and 1 (each within the scatter of the next). At a limit, above all of these: compound 4.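

In this assay compound 4 gives > 10000 nM, which is a limit of the assay and not a number: the limit of > 10000 nM in this assay, at which 1 of the 4 values shown sits.

The steps to it are therefore floors only: an at least 1.1-fold higher number from compound 3 to compound 4 (0.06 log units; that floor lies within the scatter), an at least 1.6-fold higher number from compound 2 to compound 4 (0.20 log units; that floor lies within the scatter) and an at least 1.0-fold higher number from compound 1 to compound 4 (0.04 log units; that floor lies within the scatter). Among the four aryl groups shown at this place, opposite the ring nitrogen, only 2,4-difluorophenyl gives no number, whereas compound 1, compound 2 and compound 3 give numbers within the scatter of each other, so a move beyond the scatter for this change is neither shown nor ruled out.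

Going by these compounds, how far compound 4 really lies from the other three stays open. Also open, on these data alone, is whether an amine or a carboxylic acid on this aryl ring, or a longer chain in its place, would separate compounds on this read-out.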